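This account rests on a few compounds, and the source may have more. Where it says the series, first, only, none or still open, it means among the compounds named here.

In a functional assay on HeLa cells (Homo sapiens) for inhibition, read by sulforhodamine B assay (a lower number here means a stronger inhibitor, a higher number a weaker inhibitor), compound 1 `O=C1C=C(N2CCC2)C(=O)c2c1nc1n2[C@H]2OC[C@@H](O)[C@H]2OC1` reads > 16000 nM, which is a limit of the assay and not a number. Among the compounds with values here, compound 2 `O=C1C=C(Nc2ccc(I)cc2)C(=O)c2c1nc1n2[C@H]2OC[C@@H](O)[C@H]2OC1` gives 4070 nM, the only actual number so far. Compound 3 `O=C1C=C(N2CCCCC2)C(=O)c2c1nc1n2[C@H]2OC[C@@H](O)[C@H]2OC1` carries piperidin-1-yl in place of (4-iodophenyl)amino on a double-bonded ring carbon. Within the data shown here, the one measured step that bears on this, an at least 3.9-fold lower number from compound 1 to compound 2 (0.59 log units; beyond the scatter), came with (4-iodophenyl)amino entering, and here that group leaves. A step of a 2.5-fold higher number from compound 2 to compound 3 (0.39 log units; beyond the scatter) is therefore expected, toward a weaker inhibitor and somewhat smaller than the measured one. For compound 3 the estimated value is 10000 nM, with an expected range of 3500 nM to 30000 nM.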

Compound 3, half-maximal inhibitory concentration: > 16000 nM
Compound 3 ended at the assay's limit (the forecaster's own chance of this, stated with the estimate: 40%); middle value at least 1.6-fold (0.20 log units) away from the limit.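

In this assay there is an at least 3.9-fold higher number from compound 2 to compound 3 (0.59 log units; beyond the scatter) when piperidin-1-yl replaces (4-iodophenyl)amino on this double-bonded ring carbon. A six-membered ring at this place is therefore not enough to keep the activity of (4-iodophenyl)amino; the aromatic, carbon-only ring and the non-aromatic ring give different results. The step between azetidin-1-yl and piperidin-1-yl cannot be read, because both compounds sit at a limit of the assay: the limit of > 16000 nM in this assay, at which 2 of the 3 values shown sit.

Which part of (4-iodophenyl)amino matters remains open: the iodine, the aromatic ring or the hydrogen on its nitrogen. Plain phenylamino or (4-chlorophenyl)amino would help separate these.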